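A few compounds are considered here, and "the series" means these few. Any claim that something is new, unique, unknown or untested is made for them only; others in the source may bear on it.

Measured compounds in this series:
- compound 1 `CC[C@H](C)[C@H](N)CN(C(=O)[C@@H]1C[C@H]1c1ccc(Cl)cc1)c1ccc(-c2ccccc2)cc1` — 4300 nM
- compound 2 `CC[C@H](C)[C@H](N)CN(C(=O)[C@@H]1C[C@H]1c1cccc(Cl)c1)c1ccc(-c2ccccc2)cc1` — 2200 nM
- compound 3 `CC[C@H](C)[C@H](N)CN(C(=O)[C@@H]1C[C@H]1c1ccc(C#N)cc1)c1ccc(-c2ccccc2)cc1` — > 25000 nM

Compound 1 and compound 2 both carry a chlorophenyl on the cyclopropane and both give a number in a functional assay for agonist activity at G protein-coupled receptor 88 (Homo sapiens), read by HTRF and cAMP accumulation; on this read-out lower numbers stand for an effect already at smaller amounts and higher numbers for an effect only at larger amounts of compound; the step of a 2.0-fold lower number from compound 1 to compound 2 (0.29 log units; within the scatter) shows that moving the chloro does not matter here. Compound 3 is different: in this assay compound 3 reached only the limit (the limit of > 25000 nM in this assay, at which 1 of the 3 values shown sits), so no number stands for it. The steps of an at least 5.8-fold higher number from compound 1 to compound 3 (0.76 log units; beyond the scatter) and an at least 11-fold higher number from compound 2 to compound 3 (1.05 log units; beyond the scatter) set the floor of how much the cyano costs against either chloro.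

Compound 4 `CC[C@H](C)[C@H](N)CN(C(=O)[C@@H]1C[C@H]1c1cc(F)ccc1F)c1ccc(-c2ccccc2)cc1` is the next compound to be measured. Compared with compound 3 the change is 2,5-difluorophenyl in place of 4-cyanophenyl on a saturated ring carbon. Of the measured steps, those that bear on it are the two leading into compound 3, since they show that a halogen-bearing phenyl on that carbon is tolerated where the cyanophenyl is not. Among the compounds with values here, two fluorines are not a chloro, and no measured compound carries a difluorophenyl, so the expectation rests on halogen versus cyano only.

Compound 4 is therefore expected to return to a measurable value, a step of an at least 5.0-fold lower number from compound 3 to compound 4 (0.69 log units; beyond the scatter) against compound 3, landing near the chloro compounds. The estimate for compound 4 in this assay is 5000 nM, within 1500 nM to 20000 nM.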

Compound 4, half-maximal effective concentration: 770 nM
Estimate against measurement, compound 4: 6.5-fold (0.81 log units) above; the whole stated range lies above it.
By their numbers in this assay, from the lowest: compound 4; then compounds 2 and 1 (each within the scatter of the next). At a limit, above all of these: compound 3.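

In this assay, compound 4 has the lowest number of the series, and the steps of a 2.9-fold lower number from compound 2 to compound 4 (0.46 log units; beyond the scatter) and a 5.6-fold lower number from compound 1 to compound 4 (0.75 log units; beyond the scatter) both lie beyond the scatter. Within the data shown here, the two chlorophenyl compounds differed only within the scatter, so this is the first sign that the choice among halogen-bearing phenyl groups on this saturated ring carbon of the cyclopropane can shift the read-out measurably, with 2,5-difluorophenyl ahead of both chlorophenyl groups. Compound 3 stays a limit and not a number, so the large step of an at least 32-fold lower number from compound 3 to compound 4 (1.51 log units; beyond the scatter) gives only a floor for the gap between 4-cyanophenyl and 2,5-difluorophenyl: the limit of > 25000 nM in this assay, at which 1 of the 4 values shown sits.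

Still open, as far as these compounds go, is whether a single fluorine on the phenyl would give the same number as the pair, or whether both fluorines are needed for the step. Also open, from the compounds shown here alone, is how a methoxy or a trifluoromethyl group on this phenyl would read out, and with it whether the loss seen with the nitrile extends to other groups that carry no halogen.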